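Cyclohexyl ester in place of the propyl ketone

The source may report more compounds than this note shows. Statements on the series, on what has been measured and on what is new or still open speak of the compounds shown alone.

In an assay on membranes from CHO cells for displacement of a labelled ligand from adenosine receptor A1 (Homo sapiens), read by scintillation counting, with a stated time of 60 min, tested at 1 uM (a lower number here means less inhibition, a higher number more inhibition at the concentration tested (going by the name of the read-out)), compound 2 `CCCC(=O)C1=C(C)NC(=O)NC1c1cccs1` gives 2%. Compound 1 `CCCC(=O)C1=C(C)NC(=O)NC1c1ccco1` gives 1% in this assay, and the two numbers lie within the scatter of each other, as the step shows: a number 1 percentage points higher from compound 1 to compound 2 (within the scatter). Compound 3 `CC1=C(c2ncc(C)o2)C(c2cccs2)NC(=O)N1` gives 21% in this assay, and here the step is beyond the scatter: a number 19 percentage points higher from compound 2 to compound 3 (beyond the scatter). Compound 2 therefore sits among the low numbers, separated clearly only from compound 3.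

Compound 4 `CC1=C(C(=O)OC2CCCCC2)C(c2cccs2)NC(=O)N1` differs from compound 2 in a single place: cyclohexyloxy in place of propyl on a carbonyl carbon. Of the measured steps, only a number 19 percentage points higher from compound 2 to compound 3 (beyond the scatter) concerns the group carried by the double-bonded ring carbon, and there the whole propylcarbonyl was exchanged, whereas compound 4 keeps the carbonyl and alters only what hangs from it. The other step, a number 1 percentage points higher from compound 1 to compound 2 (within the scatter), concerns a different place and stayed within the scatter. The change to compound 4 is thus expected to give at most a small step, upward if at all: a number 6 percentage points higher from compound 2 to compound 4 (within the scatter). Compound 4 is expected to give 8% in this assay, with a range from 0% to 25%.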

Compound 4, a percentage reported as inhibition, at one concentration (the size of the read-out at that concentration, not a potency): 7%
The estimate for compound 4 lay 1 percentage points above the measured number, within the range that was stated.
By their numbers in this assay, from the lowest: compounds 1, 2 and 4 (each within the scatter of the next); then compound 3.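

In this assay the step is a number 5 percentage points higher from compound 2 to compound 4 (within the scatter) and so, on this carbonyl carbon, cyclohexyloxy with its six-membered ring and one hydrogen-bond acceptor reads the same as propyl. The earlier step of a number 19 percentage points higher from compound 2 to compound 3 (beyond the scatter) exchanged the whole propylcarbonyl, whereas this change keeps the carbonyl and shows that altering only what hangs from it, at least with this group, produces no step beyond the scatter. No measurement at hand offers an explanation for this result.

On these data alone, it remains open whether an amine, a carboxylic acid or a longer chain on this carbonyl carbon would also leave the number within the scatter. Also open, as far as these compounds go, is whether cyclohexyloxy would read the same with furan-2-yl in place of thiophen-2-yl on the saturated ring carbon.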